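This account rests on a few compounds, and the source may have more. Where it says the series, first, only, none or still open, it means among the compounds named here.

Compound 3 `CCOc1ccc(C(=O)NCc2ccc(NS(C)(=O)=O)cc2Cl)cc1` gives 1.8 h in an ADME assay on microsomes from liver (Rattus norvegicus, strain Sprague-Dawley) for metabolic stability, read by HPLC, using NADPH, with stated times of 5 min and 60 min, tested at 10 uM (a lower number here means that the compound disappears faster, a higher number that the compound lasts longer), within the scatter of both compound 1 `CS(=O)(=O)Nc1ccc(CNC(=O)c2ccc(C3(C(F)(F)F)CC3)cc2)c(Cl)c1` at 3.03 h and compound 2 `CS(=O)(=O)Nc1ccc(CNC(=O)c2ccc(C34CC(C3)C4)cc2)c(Cl)c1` at 1.35 h. Compound 4 `CS(=O)(=O)Nc1ccc(CNC(=O)c2ccc(C3(O)COC3)cc2)c(Cl)c1` differs from compound 3 as follows: 3-hydroxyoxetan-3-yl in place of ethoxy on an aromatic carbon. This places 3-hydroxyoxetan-3-yl in place of ethoxy on an aromatic carbon. Three measured steps change the group on that carbon: a 1.7-fold lower number from compound 1 to compound 3 (0.23 log units; within the scatter) and a 1.3-fold higher number from compound 2 to compound 3 (0.12 log units; within the scatter) stay within the scatter, while a 2.2-fold lower number from compound 1 to compound 2 (0.35 log units; beyond the scatter) lies beyond it but is modest. None contains the entering group, so the direction is poorly defined, and no large step is expected in this assay. The expected step is a 1.2-fold higher number from compound 3 to compound 4 (0.09 log units; within the scatter). The estimate for compound 4 is 2.2 h, with an expected range of 1 h to 4.5 h.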

Compound 4, half-life: 4.23 h
The estimate for compound 4 lay 1.9-fold (0.28 log units) below the measured number, within the range that was stated.
By their numbers in this assay, from the lowest: compounds 2, 3, 1 and 4 (each within the scatter of the next, the first and the last beyond it).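

In this assay 3-hydroxyoxetan-3-yl, the only group shown on this aromatic carbon with a hydrogen-bond donor or a ring hetero atom, gives a 2.4-fold higher number from compound 3 to compound 4 (0.37 log units; beyond the scatter) and a 3.1-fold higher number from compound 2 to compound 4 (0.50 log units; beyond the scatter), both modest. Against 1-(trifluoromethyl)cyclopropyl the change gives a 1.4-fold higher number from compound 1 to compound 4 (0.14 log units; within the scatter), so compound 1 and compound 4 cannot be ordered. No measured evidence bears on this result. As far as these compounds go, whether the step follows the hydroxyl or the four-membered ring stays open, since the two enter together. Also open, from the compounds shown here alone, is how an amine or a carboxylic acid on this carbon would compare.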